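This account rests on a few compounds, and the source may have more. Where it says the series, first, only, none or still open, it means among the compounds named here.

Measured compounds:
Compound 1, `Nc1ccccc1NC(=O)c1ccc(CSC(=S)N2CCN(Cc3ccccn3)CC2)cc1` — 65.2%
Compound 2, `CN1CCN(C(=S)SCc2ccc(C(=O)Nc3ccccc3N)cc2)CC1` — 84.4%

In a functional assay on MGC-803 cells (Homo sapiens) for antiproliferative activity, read by CCK-8 assay, with a stated time of 72 h, tested at 8 uM (a higher number here means a stronger effect of the compound at the concentration tested, a lower number a weaker effect), compound 2 stands highest of the two numbers; its nearest neighbour is compound 1, and the step of a number 19.2 percentage points higher from compound 1 to compound 2 (beyond the scatter) lies beyond the scatter. Compound 3, `Nc1ccccc1NC(=O)c1ccc(CSC(=S)N2CCN(c3ccncc3)CC2)cc1`, has not yet been measured. It differs from compound 2 by pyridin-4-yl in place of methyl on an amine nitrogen in a ring, so an aromatic ring enters on the ring nitrogen where compound 2 carries only a methyl. For the measured compounds named here, the one measured step that bears on this is a number 19.2 percentage points higher from compound 1 to compound 2 (beyond the scatter), where losing an aromatic ring near that nitrogen raised the number. Putting a ring back there, even at a different atom, therefore points to a downward step of similar size rather than none. In this assay compound 3 is expected to reach about 68%, with a range from 48% to 86%. The expected step is a number 16.4 percentage points lower from compound 2 to compound 3 (beyond the scatter).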

Compound 3, a percentage reported as inhibition, at one concentration (the size of the read-out at that concentration, not a potency): 87.1%
The estimate for compound 3 lay 19.1 percentage points below the measured number, and the stated range ends below it.
By their numbers in this assay, from the lowest: compound 1; then compounds 2 and 3 (each within the scatter of the next).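

In this assay the result is a number 2.7 percentage points higher from compound 2 to compound 3 (within the scatter), so pyridin-4-yl on this amine nitrogen in a ring, with its six-membered aromatic ring, reads level with methyl, and an aromatic ring on this nitrogen does not in itself go with a lower number. The other new comparison is a number 21.9 percentage points higher from compound 1 to compound 3 (beyond the scatter), which ties the lower reading of compound 1 to the (pyridin-2-yl)methyl group specifically, not to the presence of any pyridine ring at this position. Nothing offered here accounts for this difference between the two groups.

Still open, as far as these compounds go, is whether the chain carbon or the place of the ring nitrogen matters, which (pyridin-4-yl)methyl or a directly attached pyridin-2-yl would separate. From the compounds shown here alone, how a phenyl group would read on this nitrogen also remains open.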